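This account rests on a few compounds, and the source may have more. Where it says the series, first, only, none or still open, it means among the compounds named here.

Compound 1 `COc1ccc(C(=O)CSc2nc(Cc3cccc4ccccc34)c(C(C)C)c(=O)[nH]2)cc1`: 203000 nM
Compound 2 `Cc1c(Cc2c(Cl)cccc2Cl)nc(SCC(=O)c2ccccc2)[nH]c1=O`: > 60000 nM (a limit)
Compound 3 `Cc1c(Cc2c(F)cccc2Cl)nc(SCC(=O)c2ccccc2)[nH]c1=O`: > 12000 nM (a limit)

For the measured compounds named here, in an ADME assay on MT4 cells (Homo sapiens) for cytotoxicity, read by MTT assay (on this read-out higher numbers stand for lower toxicity in this test and lower numbers for higher toxicity in this test), compound 1 gives 203000 nM, the only actual number among the three. For compound 2, > 60000 nM is a limit of the assay. For compound 3, > 12000 nM is also a limit.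

Compound 4 `COc1ccc(C(=O)CSc2nc(Cc3c(F)cccc3Cl)c(C(C)C)c(=O)[nH]2)cc1` has 2-chloro-6-fluorophenyl in place of naphthalen-1-yl on a saturated chain carbon bound to an aromatic carbon.

Going by the values given here, the only measured step, a step that the two limits leave unreadable from compound 2 to compound 3, has no readable size, and no measured step tests this swap. Only a modest, uncertain move towards lower numbers in this assay is expected. The estimated change is a 2.0-fold lower number from compound 1 to compound 4 (0.31 log units; beyond the scatter). For compound 4 the expected value is 100000 nM, with an estimated range of 20000 nM to 300000 nM.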

Compound 4, half-maximal cytotoxic concentration: > 11000 nM
Compound 4: a limit, no number; the forecaster's own chance of this, stated with the estimate: 45%; the middle value is on the limit's open side.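

For compound 4, > 11000 nM is a limit, so its step from compound 1 cannot be read. Going by these compounds, whether 2-chloro-6-fluorophenyl in place of naphthalen-1-yl moves the number in this assay at all, and how far, stays open.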